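The compounds below may be only part of what the source reports. "The series", "measured", "known", "first", "only" and "open" are said of these compounds alone.

The measured compounds:
Compound 1, `COc1ccccc1-n1nncc1CN1C(=O)C2(C(C#N)=C(N)Oc3c2c2nc4ccccc4nc2c2ccccc32)c2ccccc21`. In an ADME assay on L02 cells (Homo sapiens) for antiproliferative activity, read by MTT assay, with a stated time of 48 h (on this read-out higher numbers stand for weaker inhibition and lower numbers for stronger inhibition), compound 1 gives only a limit of the assay, > 50000 nM.
Compound 2, `CCOc1ccc(-n2nncc2CN2C(=O)C3(C(C#N)=C(N)Oc4c3c3nc5ccccc5nc3c3ccccc43)c3ccccc32)cc1`. In this assay compound 2 likewise gives only a limit, > 50000 nM.
Compound 3, `COc1ccccc1-n1nncc1CN1C(=O)C2(C(C#N)=C(N)Oc3c(N)cc4nc5ccccc5nc4c32)c2ccccc21`. In this assay compound 3 also gives only a limit, > 50000 nM.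

Compound 1 and compound 2 share one core and differ in a single group: compound 2 carries 4-ethoxyphenyl in place of 2-methoxyphenyl on an aromatic nitrogen. With both values sitting at a limit, this change gives a step that the two limits leave unreadable from compound 1 to compound 2. Compound 3 is built on a different core; how the core of compound 3 differs from the core of compound 1 is not broken down here. Compound 4, `CCOc1ccc(-n2nncc2CN2C(=O)C3(C(C#N)=C(N)Oc4c(N)cc5nc6ccccc6nc5c43)c3ccccc32)cc1`, has not yet been measured. It carries 4-ethoxyphenyl in place of 2-methoxyphenyl on an aromatic nitrogen on the core of compound 3, and the surroundings of the change are described in exactly the same words as for the change between compound 1 and compound 2, so it is the same change. All three measured values sit at the limit of > 50000 nM in this assay, at which 3 of the 3 values shown sit, so the measured step has no readable size or direction, and there is nothing to suggest that this change turns a limit into a number. For the step from compound 3 to compound 4 the expectation is a step that the limit leaves unreadable from compound 3 to compound 4, resting on compound 3 at > 50000 nM and on (the limit of > 50000 nM in this assay, at which 3 of the 3 values shown sit). Compound 4 is therefore expected to give about 80000 nM, somewhere between 30000 nM and 300000 nM, and most probably it will again be reported only as a limit.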

Compound 4, half-maximal inhibitory concentration: > 50000 nM
Compound 4 was reported as a limit (the forecaster's own chance of this, stated with the estimate: 85%); the middle value lies beyond the limit too.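

Compound 3 and compound 4 are both reported only as a limit in this assay, so no size or direction can be read for the swap of 2-methoxyphenyl for 4-ethoxyphenyl between them, because the only thing measured is the shared limit: the limit of > 50000 nM in this assay, at which 4 of the 4 values shown sit. The compounds shown leave open how strongly any of them acts in this assay and whether this swap matters at all on either core.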